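A few compounds are considered here, and "the series" means these few. Any claim that something is new, unique, unknown or untested is made for them only; others in the source may bear on it.

Values in an ADME assay (liver) for metabolic stability, with Liver microsome (Homo sapiens) as the target, using microsomes and NADPH, with a stated time of 30 min, tested at 1 uM; a lower number here means slower removal, a higher number faster removal of the compound:
Compound 1 `CS(=O)(=O)Nc1cccc(-c2cc(C(O)(C(F)(F)F)C(F)(F)F)cnc2N2CCN(S(=O)(=O)c3ccc(N)nc3)CC2)c1`: 40 mL.min-1.g-1
Compound 2 `Nc1ccc(S(=O)(=O)N2CCN(c3ncc(C(O)(C(F)(F)F)C(F)(F)F)cc3-c3cncc(F)c3)CC2)cn1`: 24 mL.min-1.g-1
Compound 3 `COc1ccc(-c2cc(C(O)(C(F)(F)F)C(F)(F)F)cnc2N2CCN(S(=O)(=O)c3ccc(N)nc3)CC2)cn1`: 25 mL.min-1.g-1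

At 25 mL.min-1.g-1, compound 3 lies within the scatter of both other compounds. Compound 4 `Cc1nc2cc(-c3cc(C(O)(C(F)(F)F)C(F)(F)F)cnc3N3CCN(S(=O)(=O)c4ccc(N)nc4)CC3)ccc2o1` carries 2-methyl-1,3-benzoxazol-5-yl in place of 6-methoxypyridin-3-yl on an aromatic carbon. Three measured swaps at this same place bear on the change: a 1.7-fold lower number from compound 1 to compound 2 (0.22 log units; within the scatter), a 1.6-fold lower number from compound 1 to compound 3 (0.20 log units; within the scatter) and a 1.0-fold higher number from compound 2 to compound 3 (0.02 log units; within the scatter). None leaves the scatter, so no step beyond it is expected in this assay. Going by the values given here, no measured compound carries the entering group, however, so the range stays wide. The expected change is a 1.2-fold higher number from compound 3 to compound 4 (0.08 log units; within the scatter). For compound 4 the estimate is 30 mL.min-1.g-1, with an expected range of 15 mL.min-1.g-1 to 60 mL.min-1.g-1.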

Compound 4, intrinsic clearance in microsomes: < 14 mL.min-1.g-1
Compound 4: only a limit was reported; the forecaster's own chance of this, stated with the estimate: 2%; middle value at least 2.1-fold (0.33 log units) away from the limit.
By their numbers in this assay, from the lowest: compounds 2, 3 and 1 (each within the scatter of the next). At a limit, below all of these: compound 4.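

In this assay compound 4 gives only a limit, not a number: the limit of < 14 mL.min-1.g-1 in this assay, at which 1 of the 4 values shown sits. With 2-methyl-1,3-benzoxazol-5-yl, this place shows its first step beyond the scatter, an at least 2.8-fold lower number from compound 1 to compound 4 (0.45 log units; beyond the scatter). Against the two pyridine groups, the floors of an at least 1.7-fold lower number from compound 3 to compound 4 (0.25 log units; that floor lies within the scatter) and an at least 1.7-fold lower number from compound 2 to compound 4 (0.23 log units; that floor lies within the scatter) lie within the scatter, so a real difference from either is not established.

As far as these compounds go, how far compound 4 lies past its limit stays open. The compounds shown also leave open whether the methyl group contributes, which an ethyl group or an amine in its place could test.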